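The source may report more compounds than this note shows. Statements on the series, on what has been measured and on what is new or still open speak of the compounds shown alone.

Measured compounds:
compound 1, `COC(=O)c1cc(-c2cnc(C(=O)CCc3ccc(-c4ccccc4)cc3)o2)ccn1` — 1.5 nM
compound 2, `O=C(O)c1cccc(-c2cnc(CCCc3ccc(-c4ccccc4)cc3)o2)n1` — 10000 nM

In an assay for inhibition of Fatty-acid amide hydrolase 1 (Rattus norvegicus) (a lower number here means a stronger inhibitor, a higher number a weaker inhibitor), compound 1 gives 1.5 nM, the lowest of the two numbers, and compound 2 gives 10000 nM, a gap far beyond the scatter. Compound 3, `NC(=O)c1cccc(-c2cnc(C(=O)CCc3ccc(-c4ccccc4)cc3)o2)n1`, is not yet measured. It differs from compound 1 in one place: 6-carbamoylpyridin-2-yl in place of 2-(methoxycarbonyl)pyridin-4-yl on an aromatic carbon. Among the compounds with values here, no step between measured compounds isolates this change, so the expectation rests on compound 1 alone. Compound 3 is expected to stay close to compound 1, with a step of a 2.0-fold higher number from compound 1 to compound 3 (0.30 log units; within the scatter) not clearly beyond the scatter. For compound 3 the estimate in this assay is 3 nM, within 0.5 nM to 20 nM.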

Compound 3, inhibition constant: 1.2 nM
Estimate against measurement, compound 3: 2.5-fold (0.40 log units) above, within the range that was stated.
By their numbers in this assay, from the lowest: compounds 3 and 1 (each within the scatter of the next); then compound 2.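

In this assay, placing 6-carbamoylpyridin-2-yl instead of 2-(methoxycarbonyl)pyridin-4-yl on the aromatic carbon next to the ring oxygen gives a 1.3-fold lower number from compound 1 to compound 3 (0.10 log units; within the scatter), so this position takes either group with no step beyond the scatter. The entering group carries 1 hydrogen-bond donor where the leaving group has 0, and the numbers still stay within the scatter of each other. Nothing shown here explains this. Within the data shown here, the single step changes both the substituent and how its ring is attached, so their separate contributions remain open. Going by these compounds, whether an amine or a nitrile in place of the carbamoyl group would keep the number is also open.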